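Working notes on the carbonyl-side ring of the series

This account rests on a few compounds, and the source may have more. Where it says the series, first, only, none or still open, it means among the compounds named here.

Compound 3 `COc1ccc(/C=N/N(C)C(=O)c2ccccc2)cc1OC` carries the unsubstituted ring on the carbonyl side. In a functional assay on the whole organism (lung, strain A/J) for inhibition, with Mus musculus as the target, with stated times of 1 h and 18 h, at a dose of 100 umol/kg by the oral route (on this read-out higher numbers stand for more inhibition at the one dose given (going by the name of the read-out) and lower numbers for less inhibition), compound 3 gives 68%. Compound 2 `COc1ccc(C(=O)N(C)/N=C/c2ccc(OC)c(OC)c2)cc1` gives 68% in this assay, and compound 1 `COc1ccc(/C=N/N(C)C(=O)c2ccccc2OC)cc1OC` gives 53%. Compound 3 therefore stands level with compound 2 at the digits shown, the two together the highest of the three numbers, while compound 1 sits furthest away: the step of a number 15 percentage points higher from compound 1 to compound 3 (beyond the scatter) lies beyond the scatter, as does a number 15 percentage points higher from compound 1 to compound 2 (beyond the scatter). The step of no change at the digits printed from compound 2 to compound 3 (within the scatter) stays within the scatter.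

Compound 4 `COc1ccc(/C=N/N(C)C(=O)c2ccc(O)cc2)cc1OC` differs from compound 3 in one place: hydroxy in place of hydrogen on an aromatic carbon. Among the measured compounds shown here, no measured pair shows a hydroxy entering, so the expectation rests on neighbouring changes. The closest comparison is no change at the digits printed from compound 2 to compound 3 (within the scatter), where a methoxy gave way to hydrogen on an aromatic carbon of that ring and the number did not move beyond the scatter. For the measured compounds named here, the only change that did move the number, a number 15 percentage points higher from compound 1 to compound 2 (beyond the scatter), concerns a shift of the methoxy between ring positions, which compound 4 does not make. A step of about a number 3 percentage points lower from compound 3 to compound 4 (within the scatter) is therefore expected, none beyond the scatter. Compound 4 is estimated at 65%, with a range from 45% to 85%.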

Compound 4, a percentage reported as inhibition, in the whole organism at one dose (the size of the read-out at that dose, not a potency): 60%
Beside the measured number, compound 4's estimate is 5 percentage points above it, within the range that was stated.
By their numbers in this assay, from the lowest: compounds 1, 4, 2 and 3 (each within the scatter of the next, the first and the last beyond it).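

In this assay, the step of a number 8 percentage points lower from compound 3 to compound 4 (within the scatter) shows that phenyl to 4-hydroxyphenyl on the carbonyl side leaves the number within the scatter, and the step of a number 8 percentage points lower from compound 2 to compound 4 (within the scatter) shows the same for hydrogen in place of methyl on the oxygen, so hydrogen, methoxy and hydroxy at this place cannot be told apart on this read-out. Compound 4 also differs from the two earlier compounds in its relation to the 2-methoxyphenyl compound: the step of a number 7 percentage points higher from compound 1 to compound 4 (within the scatter) stays within the scatter, whereas the steps from compound 1 to compound 2 and to compound 3 lie beyond it. Nothing available accounts for any of these steps.

On these data alone, whether an amine, a carboxylic acid or a longer chain such as ethoxy at this place would also stay within the scatter of compound 3 remains open. The read-out gives the size of inhibition at a single dose and not a potency, so the compounds shown cannot say whether compound 2, compound 3 and compound 4 would still sit together at other doses.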